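A few compounds are considered here, and "the series" means these few. Any claim that something is new, unique, unknown or untested is made for them only; others in the source may bear on it.

In a functional assay on MDA-MB-231 cells (Homo sapiens) for antiproliferative activity, read by MTT assay, with a stated time of 48 h (on this read-out lower numbers stand for stronger inhibition and higher numbers for weaker inhibition), the two measured compounds share a common core and both stop at the edge of the assay. Compound 1 `Cc1oc2c3c(ccc2c(=O)c1C)OC[C@H]1[C@@H]3C2=C(CCCC2=O)OC1(C)C` gives > 100000 nM in this assay, which is a limit and not a measured number. Compound 2 `Cc1nn(-c2ccccc2)c2c1[C@@H]1c3c(ccc4c(=O)c(C)c(C)oc34)OC[C@@H]1C(C)(C)O2` returns > 100000 nM in this assay, again a limit rather than a number. Both values therefore sit together at the limit of > 100000 nM in this assay, at which 2 of the 2 values shown sit. Among the compounds with values here, no step between measured compounds can be stated in this assay; the two results are limits, and where compound 2 truly stands above that edge is not known.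

Compound 3 `Cc1nn(-c2ccccc2)c2c1[C@@H]1c3c(ccc4c(=O)c(-c5ccccc5)c(C)oc34)OC[C@@H]1C(C)(C)O2` is not yet measured. It differs from compound 2 by phenyl in place of methyl on an aromatic carbon. With nothing but two limits to draw on, the step expected from compound 2 to compound 3 in this assay is a number no higher from compound 2 to compound 3 (the limit leaves the size open), that is, none beyond the scatter. Compound 3 is accordingly estimated at 100000 nM in this assay, with a range from 20000 nM to 300000 nM, and the most likely outcome is that the assay reports only a limit once more.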

Compound 3, half-maximal inhibitory concentration: > 100000 nM
Compound 3 gave a limit, no number; the forecaster's own chance of this, stated with the estimate: 70%; the middle value sits exactly at the limit.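

No step can be read between compound 2 and compound 3 in this assay, since phenyl in place of methyl leaves both results as limits and not numbers: the limit of > 100000 nM in this assay, at which 3 of the 3 values shown sit.

The compounds shown leave open where compound 1, compound 2 and compound 3 truly stand past that edge, and whether phenyl in place of methyl alters antiproliferative activity at all.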